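The source may hold more compounds than are shown below. What is called first, only, known or untested is meant among the compounds shown, and "the series" means these compounds.

Measured in a functional assay on A-375 cells (Homo sapiens) for antiproliferative activity; a higher number here means a weaker inhibitor, a lower number a stronger inhibitor:
- compound 1 `O=C(Nc1ccc(-c2ccncc2)cc1)C1CCCN(Cc2ccc(F)c(F)c2)C1`: 600 nM
- compound 2 `O=C(Nc1ccc(-c2cccnc2)cc1)C1CCCN(Cc2ccc(F)c(F)c2)C1`: 610 nM

Only these two numbers are known so far. Compound 2, at 610 nM, cannot be told apart from the other value. Going by the values given here, the one measured step, a 1.0-fold higher number from compound 1 to compound 2 (0.01 log units; within the scatter), puts pyridin-3-yl in place of pyridin-4-yl on an aromatic carbon, and it lies within the scatter.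

Compound 3 `O=C(Nc1ccc(-c2nccs2)cc1)C1CCCN(Cc2ccc(F)c(F)c2)C1` changes the same place, on an aromatic carbon of a six-membered aromatic ring of carbon only, para to a large group. Here 1,3-thiazol-2-yl stands in place of pyridin-3-yl (1,3-thiazol-2-yl in place of pyridin-3-yl on an aromatic carbon). The measured step bears on this change only in part, since it swapped one pyridinyl group for another, while here a five-membered aromatic ring enters. Among the compounds with values here, no measured step covers such a ring exchange. Resting on that single flat step, no change beyond the scatter is expected in this assay, though a shift in either direction stays open.

The expected change is a 1.1-fold higher number from compound 2 to compound 3 (0.06 log units; within the scatter), which is only an estimate. Compound 3 is estimated at 700 nM, with an expected range from 250 nM to 2000 nM.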

Compound 3, half-maximal inhibitory concentration: 240 nM
The estimate for compound 3 lay 2.9-fold (0.46 log units) above the measured number; the whole stated range lies above it.
By their numbers in this assay, from the lowest: compound 3; then compounds 1 and 2 (each within the scatter of the next).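

In this assay, the place on the aromatic carbon para to a large group turns out to respond to the nature of the ring it carries: 1,3-thiazol-2-yl in place of pyridin-3-yl gives a 2.5-fold lower number from compound 2 to compound 3 (0.41 log units; beyond the scatter), and in place of pyridin-4-yl it gives a 2.5-fold lower number from compound 1 to compound 3 (0.40 log units; beyond the scatter). The two steps agree, so the modest shift holds against both pyridinyl groups, and the flat step between those two groups says only that they cannot be told apart, not that the place is insensitive to every exchange. No evidence is available that accounts for this shift.

The 1,3-thiazol-2-yl group differs from the pyridinyl groups at once in ring size, in its sulfur and in its second hetero atom, so these three compounds cannot show which of those differences goes with the lower number. As far as these compounds go, it remains open how a thiophen-2-yl or a 1,3-oxazol-2-yl group would compare at this place, and whether the shift would carry over to other groups on the core of compound 3.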